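Swapping the urea tail of compound 2 for an isoxazole

The compounds below may be only part of what the source reports. "The series", "measured", "known", "first", "only" and "open" are said of these compounds alone.

Three measured compounds share one core and differ only in the group on the far side of the urea. Compound 1 `O=C(Nc1ccc(Nc2ncnc3c2OCCN3)cc1)Nc1ccc(Cl)c(C(F)(F)F)c1` carries a phenyl bearing chloro and trifluoromethyl groups; in an assay on isolated protein for inhibition of proto-oncogene tyrosine-protein kinase receptor Ret variant V804L (Homo sapiens), read by 33P incorporation, with stated times of 15 min and 40 min (on this read-out lower numbers stand for stronger inhibition and higher numbers for weaker inhibition), compound 1 gives 285 nM. Compound 2 `COc1cccc(NC(=O)Nc2ccc(Nc3ncnc4c3OCCN4)cc2)c1` carries a methoxyphenyl instead. In this assay compound 2 sits at the limit > 10000 nM, which is a boundary of the assay and not a number. Compound 3 `O=C(Nc1ccc(Nc2ncnc3c2OCCN3)cc1)Nc1cccc(-c2ccccc2)c1` has a phenyl in place of the methoxy. In this assay compound 3 likewise sits at the limit > 10000 nM. The step that the two limits leave unreadable from compound 2 to compound 3 therefore cannot be read, since the limit of > 10000 nM in this assay, at which 2 of the 3 values shown sit, hides both of its ends.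

Compound 4 `CC(C)(C)c1cc(NC(=O)Nc2ccc(Nc3ncnc4c3OCCN4)cc2)no1` is the next variation: 5-(tert-butyl)-1,2-oxazol-3-yl in place of 3-methoxyphenyl on an amide-type nitrogen. Within the data shown here, no measured step bears directly on this change, and compound 2 itself stands only at a limit, so the expectation for compound 4 is loose. The step of an at least 4.0-fold lower number from compound 2 to compound 4 (0.60 log units; beyond the scatter) is expected to point toward stronger inhibition, though it cannot be sized from a starting point that is a limit. Compound 4 is estimated at 2500 nM, within a range from 300 nM to 10000 nM.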

Compound 4, half-maximal inhibitory concentration: 58 nM
The estimate for compound 4 lay 43-fold (1.63 log units) above the measured number; measured number outside the range, below it.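

Putting 5-(tert-butyl)-1,2-oxazol-3-yl in place of 3-methoxyphenyl on an amide-type nitrogen gives an at least 170-fold lower number from compound 2 to compound 4 (2.23 log units; beyond the scatter), so at this position the group need not be a six-membered aromatic ring of carbon only. Among these compounds, until now, the only measurable number in this assay belonged to a phenyl bearing chloro and trifluoromethyl groups, where compound 1 gives 285 nM, whereas compound 4 gives 58 nM with a five-membered aromatic ring with 2 hetero atoms. In this assay compound 2 gives > 10000 nM, which is a limit of the assay and not a number.

Compound 4 changes the ring and adds the tert-butyl group in a single step, so the compounds shown do not tell how much of the difference belongs to each, and a 1,2-oxazol-3-yl ring carrying methyl or cyclopropyl in place of tert-butyl would help to separate them. The full size of the step, like any step between the two compounds at the limit, cannot be read because the starting value is not a number: the limit of > 10000 nM in this assay, at which 2 of the 4 values shown sit.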